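A few compounds are considered here, and "the series" means these few. Any claim that something is new, unique, unknown or untested is made for them only; others in the source may bear on it.

Compound 1 `CC(C)CNc1c(O)cc(O)c2c(=O)cc(-c3ccccc3)oc12`: 12 uM
Compound 2 `CCCNc1c(O)cc(O)c2c(=O)cc(-c3ccccc3)oc12`: 28 uM

In an ADME assay on Hippocampus (Mus musculus), read by LDH release (a higher number here means that more compound is tolerated, a lower number that less compound is tolerated), compound 2 holds the higher of the two numbers, at 28 uM. Compound 3 `C=CCNc1c(O)cc(O)c2c(=O)cc(-c3ccccc3)oc12` departs from it by vinyl in place of ethyl on a saturated chain carbon bound to a nitrogen on an aromatic ring, with vinyl in place of ethyl on a saturated chain carbon bound to a nitrogen on an aromatic ring. Within the data shown here, only one measured step bears on this, a 2.3-fold higher number from compound 1 to compound 2 (0.37 log units; beyond the scatter). Among the measured compounds shown here, that modest step is a different change, hydrogen in place of methyl, and no measured step shows vinyl in place of ethyl. A shift beyond the scatter in this assay is therefore not expected, and the estimate is a 1.1-fold lower number from compound 2 to compound 3 (0.05 log units; within the scatter). Compound 3 is estimated at 25 uM, with an expected range of 11 uM to 55 uM.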

Compound 3, half-maximal toxic concentration: 11 uM
The estimate for compound 3 lay 2.3-fold (0.36 log units) above the measured number, and the stated range covers the measured number.
By their numbers in this assay, from the lowest: compounds 3 and 1 (each within the scatter of the next); then compound 2.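

In this assay, the double bond matters at this position: vinyl in place of ethyl on a saturated chain carbon bound to a nitrogen on an aromatic ring gives a 2.5-fold lower number from compound 2 to compound 3 (0.41 log units; beyond the scatter). Vinyl in place of isopropyl gives a 1.1-fold lower number from compound 1 to compound 3 (0.04 log units; within the scatter), so compound 1 and compound 3 cannot be told apart, and only compound 2 stands clear of the other two. Nothing at hand accounts for this shift. On these data alone, whether a longer chain or a cyclopropyl group in this place would read like compound 2 or like compound 3 remains open.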